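This account rests on a few compounds, and the source may have more. Where it says the series, first, only, none or still open, it means among the compounds named here.

Measured compounds:
compound 1, `Cc1ccc(C(=O)Nc2nc(Cl)c3cn(CC(C)(C)C)nc3n2)cc1`, 5000 nM
compound 2, `CCOC(=O)c1nc(NC(=O)c2ccc(C(F)(F)F)cc2)nc2nn(CC(C)(C)C)cc12`, 1300 nM

In an assay on CHO cells for displacement of a labelled ligand from adenosine receptor A3 (Homo sapiens), read by scintillation counting, with a stated time of 3 h (a lower number here means a stronger inhibitor, a higher number a weaker inhibitor), compound 2 gives 1300 nM, the lower of the two numbers shown; compound 1 gives 5000 nM, a gap that lies beyond the scatter. For the measured compounds named here, the two compounds differ in more than one place, so their values show only that compound 1 is the weaker of the pair. Compound 3, `CCOC(=O)c1nc(NC(=O)c2ccc(C)cc2)nc2nn(CC(C)(C)C)cc12`, is not yet measured; it differs from compound 2 by methyl in place of trifluoromethyl on an aromatic carbon. Going by the values given here, no measured pair shows this change on its own. Among the compounds with values here, compound 1, the only compound carrying the methyl, has the weaker number, but it also differs from compound 2 in its core, so the size of this step is uncertain. A modest loss is expected, a step of a 1.9-fold higher number from compound 2 to compound 3 (0.28 log units; within the scatter). The estimate for compound 3 in this assay is 2500 nM, with a range from 1000 nM to 8000 nM.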

Compound 3, inhibition constant: 900 nM
Compound 3: the middle estimate sits 2.8-fold (0.44 log units) above what was measured; the whole stated range lies above it.
By their numbers in this assay, from the lowest: compounds 3 and 2 (each within the scatter of the next); then compound 1.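

In this assay the change from 4-(trifluoromethyl)phenyl to 4-methylphenyl can now be read on its own on the shared core (a 1.4-fold lower number from compound 2 to compound 3 (0.16 log units; within the scatter)), and at this place the two groups cannot be told apart. With the methyl held the same, ethoxycarbonyl in place of chloro on an aromatic carbon gives a step beyond the scatter (a 5.6-fold lower number from compound 1 to compound 3 (0.74 log units; beyond the scatter)), so the difference seen so far goes with that other place and not with the methyl. Nothing available here accounts for either step.

On these data alone, whether an amine or a methoxy group on the six-membered aromatic ring would shift the number beyond the scatter remains open. So does whether a carboxylic acid or an amide in place of the ethoxycarbonyl would hold the lower number.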